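Dioxolane side chains: removing hydroxymethyl from compound 3

The compounds below may be only part of what the source reports. "The series", "measured", "known", "first", "only" and "open" are said of these compounds alone.

compound 1 `O=C1c2c[n+]([O-])c3ccccc3c2C(=O)c2c1c1ccccc1n2Cc1cn([C@H]2O[C@H](CO)[C@@H](O)[C@H]2O)nn1`: 2680 nM
compound 2 `CC1(C)OCC(Cn2cc(Cn3c4c(c5ccccc53)C(=O)c3c[n+]([O-])c5ccccc5c3C4=O)nn2)O1`: 80 nM
compound 3 `CC1(C)O[C@@H](CO)[C@H](Cn2cc(Cn3c4c(c5ccccc53)C(=O)c3c[n+]([O-])c5ccccc5c3C4=O)nn2)O1`: 370 nM

In a functional assay on A549 cells (Homo sapiens) for cytotoxicity, read by MTT assay, with a stated time of 72 h (a lower number here means a stronger inhibitor, a higher number a weaker inhibitor), compound 3 gives 370 nM, the middle of the three numbers. On one side stands a 4.6-fold higher number from compound 2 to compound 3 (0.67 log units; beyond the scatter), and on the other 7.2-fold lower number from compound 1 to compound 3 (0.86 log units; beyond the scatter).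

The next compound to be measured is compound 4 `CC1(C)OC[C@H](Cn2cc(Cn3c4c(c5ccccc53)C(=O)c3c[n+]([O-])c5ccccc5c3C4=O)nn2)O1`. It differs from compound 3 at one place: hydrogen in place of hydroxymethyl on a saturated ring carbon. In short, hydrogen stands in place of hydroxymethyl on a saturated ring carbon.

The closest evidence is a 4.6-fold higher number from compound 2 to compound 3 (0.67 log units; beyond the scatter), a modest step beyond the scatter. There, the 5-(hydroxymethyl)-2,2-dimethyl-1,3-dioxolan-4-yl group replaces the 2,2-dimethyl-1,3-dioxolan-4-yl group, which is the same exchange run the other way. The larger 34-fold lower number from compound 1 to compound 2 (1.53 log units; beyond the scatter) and the modest 7.2-fold lower number from compound 1 to compound 3 (0.86 log units; beyond the scatter) both start from a different group on the aromatic nitrogen, so they bear on this change only indirectly.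

Going by the values given here, a modest step toward a lower number is therefore expected, roughly mirroring the single precedent. The step expected in this assay is a 4.1-fold lower number from compound 3 to compound 4 (0.61 log units; beyond the scatter). Among the compounds with values here, with only one precedent, the range is kept wide. For compound 4 the estimated value is 90 nM, with an expected range from 40 nM to 200 nM.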

Compound 4, half-maximal inhibitory concentration: 340 nM
Estimate against measurement, compound 4: 3.8-fold (0.58 log units) below, outside the stated range (above it).
By their numbers in this assay, from the lowest: compound 2; then compounds 4 and 3 (each within the scatter of the next); then compound 1.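

Reading a 1.1-fold lower number from compound 3 to compound 4 (0.04 log units; within the scatter) in this assay puts hydrogen and hydroxymethyl on this saturated ring carbon level, so the hydroxymethyl group alone cannot account for the earlier gap between compound 2 and compound 3. That gap returns as a 4.3-fold higher number from compound 2 to compound 4 (0.63 log units; beyond the scatter) with the same atoms and bonds on both sides, and the one difference left is: the fact that one of compounds 2 and 4 is drawn with a defined configuration and the other without, at the place where they differ. Compound 3 and compound 4 also stand on the same side of compound 1, with a 7.9-fold lower number from compound 1 to compound 4 (0.90 log units; beyond the scatter) for the side chain that carries no hydroxymethyl.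

Among the compounds shown, the opposite configuration at this ring carbon has no drawn counterpart, so what links the number of compound 2 to its undefined stereocentre stays open. Also open, from the compounds shown here alone, is whether an aminomethyl group, a carboxylic acid or a longer hydroxyethyl chain on this saturated ring carbon would read differently from hydrogen and hydroxymethyl.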